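This account rests on a few compounds, and the source may have more. Where it says the series, first, only, none or still open, it means among the compounds named here.

Series notes, amide variation on the shared core. Compound 1 `CC(C)(C)OC(=O)NCCNC(=O)CN1CN(c2ccccc2)C2(CCN(C(=O)c3ccc(C(C)(C)C)cc3)CC2)C1=O` gives 10900 nM in an assay on HEK293 cells for displacement of a labelled ligand from NPC1-like intracellular cholesterol transporter 1 (Homo sapiens); on this read-out lower numbers stand for stronger inhibition and higher numbers for weaker inhibition. Compound 2 `CC(C)(C)c1ccc(C(=O)N2CCC3(CC2)C(=O)N(CC(=O)NCCC(=O)O)CN3c2ccccc2)cc1` gives 11400 nM in this assay, and compound 3 `CC(C)(C)c1ccc(C(=O)N2CCC3(CC2)C(=O)N(CC(=O)N2CCCC(O)C2)CN3c2ccccc2)cc1` gives 12200 nM in this assay. Compound 3 carries the highest of the three numbers, but the gaps are small: a 1.1-fold higher number from compound 1 to compound 3 (0.05 log units; within the scatter) and a 1.1-fold higher number from compound 2 to compound 3 (0.03 log units; within the scatter), as is a 1.0-fold higher number from compound 1 to compound 2 (0.02 log units; within the scatter). Nothing among the three measured compounds separates from the others beyond the scatter.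

Compound 4 `CC(C)(C)c1ccc(C(=O)N2CCC3(CC2)C(=O)N(CC(=O)NCCCCN)CN3c2ccccc2)cc1` is the next member; against compound 3 the change is (4-aminobutyl)amino in place of 3-hydroxypiperidin-1-yl on a carbonyl carbon. Among the measured compounds shown here, the steps that bear on it are those that already swapped the group on this carbonyl carbon, from compound 1 and from compound 2 to compound 3; both stayed within the scatter, with exchanges between a ring, a carboxy-bearing chain and a carbamate-bearing chain all reading alike in this assay. The (4-aminobutyl)amino group is a further chain variant at the same carbon, so no step beyond the scatter is expected: a 1.0-fold lower number from compound 3 to compound 4 (0.01 log units; within the scatter) is the estimated step. Compound 4 is therefore expected to give about 12000 nM in this assay, with a range from 5000 nM to 30000 nM.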

Compound 4, half-maximal inhibitory concentration: 14500 nM
The estimate for compound 4 lay 1.2-fold (0.08 log units) below the measured number; measured number inside the range.
By their numbers in this assay, from the lowest: compounds 1, 2, 3 and 4 (each within the scatter of the next).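

On this carbonyl carbon, (4-aminobutyl)amino in place of 3-hydroxypiperidin-1-yl gives a 1.2-fold higher number from compound 3 to compound 4 (0.08 log units; within the scatter) in this assay and stays level with the two other chains, with a 1.3-fold higher number from compound 2 to compound 4 (0.10 log units; within the scatter) and a 1.3-fold higher number from compound 1 to compound 4 (0.12 log units; within the scatter) as the steps. A chain ending in an amine therefore joins the ring, the carboxy-bearing chain and the carbamate-bearing chain: across these four compounds, the group at this position has not moved the number beyond the scatter, and none of the four goes against that. Nothing measured here offers an explanation for this flat reading.

From the compounds shown here alone, whether any group at this carbon can separate from the others remains open, since a guanidine, an aromatic amine or a much longer alkyl chain could still read differently. Also open, going by these compounds, is whether the same flat reading would hold with changes elsewhere on the shared core.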